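From compound 1 to compound 3: chloro gives way to hydrogen

The source may report more compounds than this note shows. Statements on the series, on what has been measured and on what is new or still open speak of the compounds shown alone.

Compound 1 `O=c1n(Cc2nc3nc(Cl)ccc3n2CCCCO)c2cnccc2n1C1CC1`: > 50000 nM (a limit)
Compound 2 `N#CCCCn1c(Cn2c(=O)n(C3CC3)c3ccncc32)nc2nc(Cl)ccc21`: > 50000 nM (a limit)

In an ADME assay on HeLa cells (Homo sapiens) for cytotoxicity, read by ATP content, with a stated time of 3 days (on this read-out lower numbers stand for higher toxicity in this test and higher numbers for lower toxicity in this test), compound 1 gives > 50000 nM as a limit of the assay and not a number. Compound 2 gives > 50000 nM as a limit as well. Compound 1 therefore stands at the limit of > 50000 nM in this assay, at which 2 of the 2 values shown sit, and no number places it further. For the measured compounds named here, the only measured step is a step that the two limits leave unreadable from compound 1 to compound 2 and it lies on the chain, so it offers no size to carry over. Compound 3 `O=c1n(Cc2nc3ncccc3n2CCCCO)c2cnccc2n1C1CC1` keeps the chain of compound 1 and has hydrogen in place of chloro on an aromatic carbon, counted as hydrogen in place of chloro on an aromatic carbon in this change. Going by the values given here, with no measured step of readable size, no shift beyond the scatter is expected in this assay here. The expected change is a number no higher from compound 1 to compound 3 (the limit leaves the size open) by this estimate. For compound 3 the expected value is 50000 nM with an estimated range from 20000 nM to 100000 nM around it.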

Compound 3, half-maximal cytotoxic concentration: > 100000 nM
Compound 3: a limit, no number (the forecaster's own chance of this, stated with the estimate: 85%); at least 2.0-fold (0.30 log units) between middle value and limit.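

In this assay compound 1 and compound 3 both give limits and not numbers, so no step can be read between them. The compounds shown leave open what size, if any, the effect of hydrogen in place of chloro on an aromatic carbon has on the half-maximal cytotoxic concentration.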